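A few compounds are considered here, and "the series" means these few. Any claim that something is new, unique, unknown or untested is made for them only; others in the source may bear on it.

Compound 1 `Cc1ccc(-c2nc(CNc3ccc(C(=O)NO)cc3)n(-c3ccccc3)n2)cc1` gives 62.2% in an assay on Sf9 cells for inhibition of protein deacetylase HDAC6 (Homo sapiens), read by fluorescence, with a stated time of 40 min, tested at 100 nM (a higher number here means more inhibition at the concentration tested (going by the name of the read-out), a lower number less inhibition), the lower of the two numbers measured, while compound 2 `O=C(NO)c1ccc(NCc2nc(-c3ccc(Cl)cc3)nn2-c2ccccc2)cc1` gives 67.2%. For the measured compounds named here, the one step that bears on the present change is a number 5 percentage points higher from compound 1 to compound 2 (within the scatter), a step within the scatter. Compound 3 `O=C(NO)c1ccc(NCc2nc(-c3ccc(Cl)c(Cl)c3)nn2-c2ccccc2)cc1` differs from compound 1 by 3,4-dichlorophenyl in place of 4-methylphenyl on an aromatic carbon. Going by the values given here, no measured step covers the second chloro, so the expectation rests on that single small step alone: compound 3 is expected to show a number 4.8 percentage points higher from compound 1 to compound 3 (within the scatter), a change not beyond the scatter. Compound 3 is estimated at 67%, with a range from 50% to 82%.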

Compound 3, a percentage reported as inhibition, at one concentration (the size of the read-out at that concentration, not a potency): 34.5%
Estimate against measurement, compound 3: 32.5 percentage points above, outside the stated range (below it).
By their numbers in this assay, from the lowest: compound 3; then compounds 1 and 2 (each within the scatter of the next).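

In this assay the added chloro on the aromatic ring proves decisive, with a number 32.7 percentage points lower from compound 2 to compound 3 (beyond the scatter), although the earlier exchange of methyl for chloro stayed within the scatter. The whole change to 3,4-dichlorophenyl gives a number 27.7 percentage points lower from compound 1 to compound 3 (beyond the scatter), so the group on this carbon of the five-membered ring can shift the inhibition well beyond the scatter. Nothing available explains this loss. The compounds shown leave open whether a fluoro or a methoxy group in place of the second chloro would bring the same loss.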